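Cytotoxicity limits across three diarylamine analogues

This account rests on a few compounds, and the source may have more. Where it says the series, first, only, none or still open, it means among the compounds named here.

Measured compounds and their values:
Compound 1 `C=C[C@@](C)(/C=C/c1ccc(Nc2cccc(OC(F)(F)F)c2)cc1)CCC=C(C)C` in an ADME assay on BJ cells (Homo sapiens) for cytotoxicity, with a stated time of 72 h (on this read-out higher numbers stand for an effect only at larger amounts of compound and lower numbers for an effect already at smaller amounts), gives > 36600 nM, which is a limit of the assay rather than a number.
Compound 2 `C=C[C@@](C)(/C=C/c1ccc(Nc2ccc(OC(F)(F)F)cc2)cc1)CCC=C(C)C` in this assay gives > 36600 nM, again a limit of the assay.
Compound 3 `C=C[C@@](C)(/C=C/c1ccc(Nc2ccc(C(F)(F)F)cc2)cc1)CCC=C(C)C` in this assay gives > 36600 nM, also a limit of the assay.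

All three measured compounds share a long diene-bearing chain attached to a styrene-like unit that carries a diarylamine; they differ only in the substituent on the outer ring and where it sits. The difference between the cores of compound 1 and compound 2 is not broken down here. From compound 2 to compound 3 the change is trifluoromethyl in place of trifluoromethoxy on an aromatic carbon, and it gives a step that the two limits leave unreadable from compound 2 to compound 3; the reason the step cannot be read is the limit of > 36600 nM in this assay, at which 3 of the 3 values shown sit.

The not yet measured compound 4 `C=C[C@@](C)(/C=C/c1ccc(Nc2cccc(C(F)(F)F)c2)cc1)CCC=C(C)C` differs from compound 1 by trifluoromethyl in place of trifluoromethoxy on an aromatic carbon. This is the same kind of change as that from compound 2 to compound 3, but the surroundings differ: in compound 3 the new group sits para to a large group, whereas in compound 4 it sits meta to a large group. Since every measured value in this assay, including that of compound 1 > 36600 nM, sits at the same limit, compound 4 is expected to show a step that the limit leaves unreadable from compound 1 to compound 4, meaning no readable change. Compound 4 is therefore estimated at 50000 nM, within a range from 30000 nM to 120000 nM, most likely reported as a limit.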

Compound 4, half-maximal effective concentration: > 36600 nM
Compound 4 was reported as a limit; the forecaster's own chance of this, stated with the estimate: 85%; the middle value is on the limit's open side.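

Swapping trifluoromethoxy for trifluoromethyl between compound 1 and compound 4 gives no step that can be read, because both results are limits of the assay rather than numbers: the limit of > 36600 nM in this assay, at which 4 of the 4 values shown sit.

The compounds shown leave open how their actual values in this assay compare, and so whether the choice of group or its place on the outer ring makes any difference.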